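Ethyl in Place of Methoxy: Expecting Compound 4

The compounds below may be only part of what the source reports. "The series", "measured", "known", "first", "only" and "open" are said of these compounds alone.

Measured compounds:
compound 1, `NCc1cccc(Cn2c(N)nc3ccccc32)c1`: "not active" (no number reported)
compound 2, `CCCCCn1c(N)nc2ccc(C)cc21`: 7210 nM
compound 3, `CCCCCn1c(N)nc2c(OC)cccc21`: 3740 nM

Of the compounds shown here, three have been tested in an assay on HEK293 cells for agonist activity at Toll-like receptor 8 (Homo sapiens), read by reporter gene assay; on this read-out higher numbers stand for an effect only at larger amounts of compound and lower numbers for an effect already at smaller amounts. Compound 1 gave "not active" (no number reported), so no number is available for it. Compound 2 gave 7210 nM in this assay, and compound 3 gave 3740 nM. Among the compounds with values here, the two numbers lie within the usual scatter of each other, so compound 3 stands alongside compound 2 rather than apart from it; there is no step between measured compounds that differ in only one place, and so no measured step to lean on.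

Compound 4, `CCCCCn1c(N)nc2c(CC)cccc21`, has not yet been measured. It differs from compound 3 by ethyl in place of methoxy on an aromatic carbon. Within the data shown here, with no comparable step among the measured compounds, nothing in these data points to a change larger than the usual scatter in either direction. Compound 4 is therefore expected to give about 3500 nM in this assay, with a range from 1200 nM to 10000 nM. The expected step is a 1.1-fold lower number from compound 3 to compound 4 (0.03 log units; within the scatter), essentially none beyond the scatter.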

Compound 4, half-maximal effective concentration: 1650 nM
Compound 4: the middle estimate sits 2.1-fold (0.33 log units) above what was measured, and the stated range covers the measured number.
By their numbers in this assay, from the lowest: compound 4; then compounds 3 and 2 (each within the scatter of the next).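

In this assay, ethyl in place of methoxy on an aromatic carbon gives a 2.3-fold lower number from compound 3 to compound 4 (0.36 log units; beyond the scatter), the first step among these compounds that differs in one place, showing that the read-out responds to the group held at this position. The two groups have the same count of heavy atoms, but only methoxy carries a hydrogen-bond acceptor, so the exchange changes more than one feature at once. Nothing available ties the step to any particular feature of either group.

On these data alone, it remains open whether propyl, a longer chain, or an amine at this aromatic carbon would give a lower or a higher number than ethyl. Also open, as far as these compounds go, is whether the same exchange would give a similar step at another aromatic carbon of the shared core.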